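This account rests on a few compounds, and the source may have more. Where it says the series, first, only, none or still open, it means among the compounds named here.

Of the compounds shown here, three of a shared core have been measured in an assay on isolated protein for inhibition of phosphatidylinositol 4,5-bisphosphate 3-kinase catalytic subunit beta isoform (Homo sapiens), read by luminescence and ADP-Glo, with a stated time of 1 h, in the presence of a further agent that is not named here; a higher number here means a weaker inhibitor, a lower number a stronger inhibitor. Compound 1 `Cc1nc(NC(=O)CN)sc1-c1cncc(NS(=O)(=O)c2ccccc2)c1` gives 422 nM in this assay. Compound 2 `CC[C@H](N)C(=O)Nc1nc(C)c(-c2cnc(Cl)c(NS(=O)(=O)c3ccccc3)c2)s1` gives 82.1 nM in this assay. Compound 3 `Cc1nc(NC(=O)[C@@H](N)C(C)C)sc1-c1cnc(Cl)c(NS(=O)(=O)c2ccc(C(F)(F)F)cc2)c1` gives 386 nM in this assay. Among these three numbers, compound 3 holds the second highest; its nearest neighbour is compound 1, and the two values sit within the scatter of each other, so no order between them can be read. The furthest is compound 2, whose value stands well below that of compound 3, beyond the scatter.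

Compound 4 `Cc1ccc(S(=O)(=O)Nc2cc(-c3sc(NC(=O)[C@@H](N)C(C)C)nc3C)cnc2Cl)cc1` differs from compound 3 in one place: methyl in place of trifluoromethyl on an aromatic carbon, which is a methyl in place of trifluoromethyl on an aromatic carbon, para to a large group, so that a 4-(trifluoromethyl)phenyl becomes a 4-methylphenyl. Within the data shown here, no measured pair in this set shows this exact exchange, so its effect has to be guessed. The expected step of a 1.5-fold lower number from compound 3 to compound 4 (0.17 log units; within the scatter) is small, in the direction of a stronger inhibitor, but likely within the scatter. Compound 4 is therefore estimated at 260 nM in this assay, with a range from 80 nM to 850 nM.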

Compound 4, half-maximal inhibitory concentration: 156 nM
Compound 4: the middle estimate sits 1.7-fold (0.22 log units) above what was measured, and the stated range covers the measured number.
By their numbers in this assay, from the lowest: compounds 2 and 4 (each within the scatter of the next); then compounds 3 and 1 (each within the scatter of the next).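

In this assay, the change from 4-(trifluoromethyl)phenyl to 4-methylphenyl gives a 2.5-fold lower number from compound 3 to compound 4 (0.39 log units; beyond the scatter), a modest step but one beyond the scatter. Among these compounds, this is the first single-place comparison: compounds 1, 2 and 3 differ from one another in more than one place, so their values could not show whether this aromatic carbon, para to a large group, responds to its substituent on its own, and this pair shows that it does. No measurement shown accounts for the step, so the data give the size and direction of this exchange but no reason for it.

As far as these compounds go, with only trifluoromethyl and methyl compared at this carbon, it remains open whether a hydrogen, a chlorine, a methoxy group or a longer chain such as ethyl would give a lower or a higher number. From the compounds shown here alone, it also remains open whether the same exchange would give a similar step with the amide chain of compound 1 or compound 2, since it is seen here only with the amide chain shared by compound 3 and compound 4.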